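Ethoxy to methoxy on compound 3

The source may report more compounds than this note shows. Statements on the series, on what has been measured and on what is new or still open speak of the compounds shown alone.

In a functional assay on HCT-116 cells (Homo sapiens) for antiproliferative activity, read by sulforhodamine B assay, with a stated time of 4 days (a lower number here means a stronger inhibitor of growth, a higher number a weaker inhibitor of growth), compound 3 (`CCOc1cc(-c2nc(SCC(=O)NC(C)C)nc3[nH]cc(C#N)c23)c(Cl)cc1OC`) gives 65 nM and sits within the scatter of the other two measured compounds: compound 1 (`COc1cc(Cl)c(-c2nc(SCC(=O)NC3CC3)nc3[nH]cc(C#N)c23)cc1OC`) gives 60 nM and compound 2 (`COc1cc(Cl)c(-c2nc(SCC(=O)NC(C)(C)C)nc3[nH]cc(C#N)c23)cc1OC`) gives 50 nM in the same test. Both carry methoxy where compound 3 carries ethoxy. Compound 4 (`COc1cc(Cl)c(-c2nc(SCC(=O)NC(C)C)nc3[nH]cc(C#N)c23)cc1OC`) makes that swap on compound 3: hydrogen in place of methyl on a saturated chain carbon bound to an oxygen on an aromatic ring is the whole difference, hydrogen in place of methyl on a saturated chain carbon bound to an oxygen on an aromatic ring. For the measured compounds named here, no measured step covers this change. The only one, tert-butyl in place of cyclopropyl on an amide-type nitrogen, is a 1.2-fold lower number from compound 1 to compound 2 (0.08 log units; within the scatter) and lies elsewhere in the molecule. The expected step is a 1.2-fold lower number from compound 3 to compound 4 (0.07 log units; within the scatter) in this assay and nothing beyond the scatter is foreseen. For compound 4 the estimate is 55 nM with an expected range of 30 nM to 100 nM around it.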

Compound 4, concentration for 50% growth inhibition: 81 nM
Estimate against measurement, compound 4: 1.5-fold (0.17 log units) below, and the stated range covers the measured number.
By their numbers in this assay, from the lowest: compounds 2, 1, 3 and 4 (each within the scatter of the next).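

In this assay the change from ethoxy to methoxy gives a 1.2-fold higher number from compound 3 to compound 4 (0.10 log units; within the scatter) and so stays within the scatter: at this place, removing the methyl leaves no readable effect on growth inhibition. Changes on the amide nitrogen read the same way, with tert-butyl against isopropyl giving a 1.6-fold higher number from compound 2 to compound 4 (0.21 log units; within the scatter) and cyclopropyl against isopropyl giving a 1.4-fold higher number from compound 1 to compound 4 (0.13 log units; within the scatter) in the same test. On these data alone, whether a longer chain or an amine at the ethoxy place would also stay within the scatter remains open. Nothing available explains why these steps are small.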